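A few compounds are considered here, and "the series" means these few. Any claim that something is new, unique, unknown or untested is made for them only; others in the source may bear on it.

Working notes on the series

Compound 1 `Cc1nc2ccc(NC(=O)COc3ccc(OC(F)(F)F)cc3)cn2c1C` and compound 2 `Cc1c(C2CC2)nc2ccc(NC(=O)COc3ccc(OC(F)(F)F)cc3)cn12` share an amide-linked side chain on a common core; compound 3 `Cc1c(C2CC2)nc2ccc(-n3ccc(OCc4ccccc4)cc3=O)cn12` keeps that core but carries a benzyloxy-substituted pyridinone in its place. In an assay on CHO cells for displacement of a labelled ligand from melanin-concentrating hormone receptor 1 (Homo sapiens), read by scintillation counting, with a stated time of 1 h (on this read-out lower numbers stand for stronger inhibition and higher numbers for weaker inhibition), compound 1 gives 3.8 nM, compound 2 gives 3 nM and compound 3 gives 42 nM. Within the data shown here, compound 3 therefore stands highest of the three numbers, and its gaps to compound 1 and to compound 2 lie beyond the scatter, whereas the single step measured within the set, a 1.3-fold lower number from compound 1 to compound 2 (0.10 log units; within the scatter), lies within it.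

Compound 4 `Cc1c(C2CC2)nc2ccc(-n3ccc(OCc4ccc(Br)cc4)cc3=O)cn12` differs from compound 3 by bromo in place of hydrogen on an aromatic carbon. Among the measured compounds shown here, no measured step bears on this change: the only step available concerns the core substituent and not the benzyl ring, so it gives no direction for a halogen on that ring. With nothing in the set pointing either way, the expectation for compound 4 in this assay is a number close to that of compound 3, with any step a 1.2-fold lower number from compound 3 to compound 4 (0.08 log units; within the scatter) expected to stay within the scatter, and a wide range allowed for the lack of a guiding comparison. The estimate for compound 4 is 35 nM, expected between 10 nM and 120 nM.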

Compound 4, half-maximal inhibitory concentration: 12 nM
The estimate for compound 4 lay 2.9-fold (0.46 log units) above the measured number; the measured number falls inside the stated range.
By their numbers in this assay, from the lowest: compounds 2 and 1 (each within the scatter of the next); then compound 4; then compound 3.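

In this assay, among these compounds, the change from benzyl to 4-bromobenzyl gives a 3.5-fold lower number from compound 3 to compound 4 (0.54 log units; beyond the scatter) and is the first step in the set to lie beyond the scatter, although it is modest in size. Among the compounds shown here, the only earlier step concerned a substituent on the shared core, so this is the first measured sign that the number responds to a change at the far end of the benzyloxy group: bromo on an aromatic carbon, para to a large group, is accepted here and moves the number lower. No measurement in the set bears on the origin of this step.

A single substituent at a single place cannot show whether the step belongs to bromo itself or would also appear with chloro, methoxy, an amine or a carboxylic acid at that carbon. It also leaves open how bromo behaves elsewhere on the same ring, and whether a longer chain in place of the benzyl group would keep the lower number.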